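A ring swap at the amine-bound carbon

This account rests on a few compounds, and the source may have more. Where it says the series, first, only, none or still open, it means among the compounds named here.

Compound 1 `Clc1cc(Cl)cc(CO[C@H]2CCCN(Cc3cccnc3)[C@H]2c2ccccc2)c1`: 112000 nM
Compound 2 `Clc1cc(Cl)cc(CO[C@H]2CCCN(Cc3ncco3)[C@H]2c2ccccc2)c1`: > 200000 nM
Compound 3 `Cn1ccnc1CN1CCC[C@H](OCc2cc(Cl)cc(Cl)c2)[C@@H]1c1ccccc1`: 165000 nM

In an assay on isolated protein for activation of cGMP-dependent protein kinase 1 (Homo sapiens), read by ADP-Glo, with stated times of 120 min and 40 min (a higher number here means that more compound is needed for the effect, a lower number that less compound is needed), compound 3 holds the higher of the two numbers, and the gap to its nearest neighbour is a 1.5-fold higher number from compound 1 to compound 3 (0.17 log units; within the scatter). For compound 2 the value is a limit of the assay the limit of > 200000 nM in this assay, at which 1 of the 3 values shown sits, and not a number. Compound 4 `O=C(O)c1cncc(CN2CCC[C@H](OCc3cc(Cl)cc(Cl)c3)[C@@H]2c2ccccc2)c1` differs from compound 3 in one place: 5-carboxypyridin-3-yl in place of 1-methyl-1H-imidazol-2-yl on a saturated chain carbon bound to an amine nitrogen in a ring. Every measured step changes the ring on this same carbon, namely an at least 1.7-fold higher number from compound 1 to compound 2 (0.25 log units; that floor lies within the scatter), a 1.5-fold higher number from compound 1 to compound 3 (0.17 log units; within the scatter) and an at least 1.2-fold lower number from compound 2 to compound 3 (0.08 log units; that floor lies within the scatter), and none of them reaches beyond the scatter. A step of similar size is therefore expected, with no change beyond the scatter: a 1.3-fold lower number from compound 3 to compound 4 (0.10 log units; within the scatter). Compound 4 is estimated at 130000 nM, between 50000 nM and 250000 nM.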

Compound 4, half-maximal effective concentration: 117000 nM
Compound 4: the middle estimate sits 1.1-fold (0.05 log units) above what was measured; measured number inside the range.
By their numbers in this assay, from the lowest: compounds 1, 4 and 3 (each within the scatter of the next). At a limit, above all of these: compound 2.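

Among these compounds, compound 4 brings the first change that keeps the ring and adds a group to it, carboxy in place of hydrogen on an aromatic carbon, and in this assay this gives a 1.0-fold higher number from compound 1 to compound 4 (0.02 log units; within the scatter). Even against the smaller 1-methyl-1H-imidazol-2-yl, 5-carboxypyridin-3-yl gives a 1.4-fold lower number from compound 3 to compound 4 (0.15 log units; within the scatter). Compound 2 stands at a limit and not a number, so its step is only a floor, an at least 1.7-fold lower number from compound 2 to compound 4 (0.23 log units; that floor lies within the scatter), set by this value: the limit of > 200000 nM in this assay, at which 1 of the 4 values shown sits.

Among the compounds shown here, no step at this carbon reaches beyond the scatter, so what would lower the number here stays open. An amine or an amide in place of the carboxy, or a longer chain, remains untested among these compounds.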